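The source may report more compounds than this note shows. Statements on the series, on what has been measured and on what is new or still open speak of the compounds shown alone.

In a functional assay on HCT-116 cells (Homo sapiens) for cytotoxicity, read by MTT assay, with a stated time of 72 h (a higher number here means a weaker inhibitor, a lower number a stronger inhibitor), compound 1 `Oc1ccc(C2C/C(=N\NC(=S)N3CCOCC3)c3ccc(O)cc3O2)cc1` gives 63500 nM and compound 2 `CCCCNC(=S)N/N=C1\CC(c2ccc(O)cc2)Oc2cc(O)ccc21` gives 49300 nM. These two numbers cannot be ranked, so compound 2 stands level with compound 1. Compound 3 `Oc1ccc(C2C/C(=N\NC(=S)N3CCCCC3)c3ccc(O)cc3O2)cc1` has not yet been measured. It differs from compound 2 in one place, on a thiocarbonyl carbon, where piperidin-1-yl stands in place of butylamino: piperidin-1-yl in place of butylamino on a thiocarbonyl carbon. For the measured compounds named here, only one measured step bears on this change. It concerns the same place, with butylamino in place of morpholin-4-yl, and it is small: a 1.3-fold lower number from compound 1 to compound 2 (0.11 log units; within the scatter). Going by the values given here, with so small a step as the only guide, no shift beyond the scatter is expected in this assay. The expected change is a 1.1-fold lower number from compound 2 to compound 3 (0.04 log units; within the scatter). The estimate for compound 3 is 45000 nM, with an expected range of 20000 nM to 90000 nM.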

Compound 3, half-maximal inhibitory concentration: 50900 nM
For compound 3 the middle estimate is 1.1-fold (0.05 log units) below the measured one; measured number inside the range.
By their numbers in this assay, from the lowest: compounds 2, 3 and 1 (each within the scatter of the next).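

In this assay, the change on the thiocarbonyl carbon removes the hydrogen-bond donor of butylamino and brings in a six-membered non-aromatic ring, yet it gives a 1.0-fold higher number from compound 2 to compound 3 (0.01 log units; within the scatter) and so no readable shift. Piperidin-1-yl in place of morpholin-4-yl on the same carbon is also small, with a 1.2-fold lower number from compound 1 to compound 3 (0.10 log units; within the scatter), so all three groups shown on this carbon give numbers within the scatter of one another. No evidence is available to explain this flat result.

The compounds shown leave open whether a different group on this carbon, such as phenylamino or a butylamino chain ending in a carboxylic acid, would move the number beyond the scatter. They also leave open what a change elsewhere on the shared core would do.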